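Swapping a Nitro-Bearing Ring for a Dichloro-Bearing One

The source may hold more compounds than are shown below. What is called first, only, known or untested is meant among the compounds shown, and "the series" means these compounds.

Measured compounds:
- compound 1, `O=C1c2ccccc2C(=O)N1CCOC(=S)N(C(=O)c1ccccc1[N+](=O)[O-])c1ccc(Cl)cc1`: 21000 nM
- compound 2, `O=C1c2ccccc2C(=O)N1CCOC(=S)N(C(=O)c1ccc(Cl)c([N+](=O)[O-])c1)c1ccccc1`: 51000 nM

In an ADME assay on MT4 cells (Homo sapiens) for cytotoxicity, read by MTT assay (on this read-out higher numbers stand for lower toxicity in this test and lower numbers for higher toxicity in this test), compound 1 gives 21000 nM, the lowest of the two numbers shown, and compound 2 gives 51000 nM, a gap beyond the usual scatter. Compound 3, `O=C1c2ccccc2C(=O)N1CCOC(=S)N(C(=O)c1cccc(Cl)c1Cl)c1ccc(Cl)cc1`, has not yet been tested. It differs from compound 1 in one place: 2,3-dichlorophenyl in place of 2-nitrophenyl on a carbonyl carbon. Among the measured compounds shown here, no measured pair shows the effect of this change, so no step can be read from the data. A small step is expected from compound 1 to compound 3 in this assay, toward a lower number, though it may well stay within the scatter; the estimate for compound 3 is 15000 nM with a range from 5000 nM to 50000 nM, which amounts to a step of a 1.4-fold lower number from compound 1 to compound 3 (0.15 log units; within the scatter).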

Compound 3, half-maximal cytotoxic concentration: 54000 nM
Compound 3: the middle estimate sits 3.6-fold (0.56 log units) below what was measured; the measured number lies above the stated range.
By their numbers in this assay, from the lowest: compound 1; then compounds 2 and 3 (each within the scatter of the next).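

In this assay, among the compounds shown here, putting 2,3-dichlorophenyl in place of 2-nitrophenyl on a carbonyl carbon gives a modest change (a 2.6-fold higher number from compound 1 to compound 3 (0.41 log units; beyond the scatter)), the first comparison here between compounds that differ in one place. It shows that the group at this position can shift the read-out, here toward lower toxicity in this test. Nothing available explains the shift.

As far as these compounds go, whether it follows the loss of the nitro group or the gain of the chlorines stays open. So does how an unsubstituted phenyl or an aminophenyl would read at this carbonyl.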